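The source may hold more compounds than are shown below. What is called first, only, known or untested is meant among the compounds shown, and "the series" means these compounds.

Measured compounds and their numbers in a functional assay on T47D cells (Homo sapiens) for cytotoxicity, read by MTT assay, with a stated time of 48 h; on this read-out higher numbers stand for weaker inhibition and lower numbers for stronger inhibition:
- compound 1, `O=C(O[C@H]1C[C@H](n2cc(F)c(=O)[nH]c2=O)O[C@@H]1COP(=O)(O)Oc1ccccc1)c1ccccc1`: 6880 nM
- compound 2, `CCCCCCCCCc1ccc(OP(=O)(O)OC[C@H]2O[C@@H](n3cc(F)c(=O)[nH]c3=O)C[C@@H]2OC(=O)c2ccccc2)cc1`: 26700 nM
- compound 3, `C[n+]1cccc(OP(=O)([O-])OC[C@H]2O[C@@H](n3cc(F)c(=O)[nH]c3=O)C[C@@H]2OC(=O)c2ccccc2)c1`: 3910 nM

Compound 3 has the lowest number of the three in this assay, but its gap to compound 1 is within the scatter, so the two cannot be ordered; only compound 2 stands clearly apart from it. The step of a 1.8-fold lower number from compound 1 to compound 3 (0.25 log units; within the scatter) shows that exchanging the aryl part of the phosphate for the charged pyridinium variant did not move the number beyond the scatter.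

Compound 4, `O=C(O[C@H]1C[C@H](n2cc(F)c(=O)[nH]c2=O)O[C@@H]1COP(=O)([O-])Oc1ccc[n+](Cc2ccccc2)c1)c1ccccc1`, carries the change (phenyl in place of hydrogen on a saturated chain carbon bound to an aromatic nitrogen). The measured step most like it is a 3.9-fold higher number from compound 1 to compound 2 (0.59 log units; beyond the scatter), where carbon was also added to the aryl part of the phosphate and the number rose. The present addition is smaller than the nonyl chain, and it sits on the saturated carbon at the aromatic nitrogen rather than on the ring itself, so a weaker version of that effect, if any, is the working assumption. Among the measured compounds shown here, no measured pair probes the saturated carbon on the pyridinium directly.

The expected step is a 1.7-fold higher number from compound 3 to compound 4 (0.22 log units; within the scatter), a modest rise in the number that may not clear the scatter. Compound 4 is therefore estimated at 6500 nM in this assay, with a range of 2500 nM to 17000 nM.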

Compound 4, half-maximal inhibitory concentration: 3430 nM
For compound 4 the middle estimate is 1.9-fold (0.28 log units) above the measured one; measured number inside the range.
By their numbers in this assay, from the lowest: compounds 4, 3 and 1 (each within the scatter of the next); then compound 2.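

In this assay, the step of a 1.1-fold lower number from compound 3 to compound 4 (0.06 log units; within the scatter) shows that the saturated chain carbon bound to an aromatic nitrogen accepts phenyl in place of hydrogen (methyl to benzyl), with compound 3 and compound 4 remaining within the scatter of each other. The earlier step of a 3.9-fold higher number from compound 1 to compound 2 (0.59 log units; beyond the scatter), with nonyl on an aromatic carbon, is not repeated here, so across these compounds added carbon in the aryl part of the phosphate does not by itself go with a higher number; compound 4 goes against that reading, and compound 2 alone stands apart. Nothing available bears on why the benzyl and methyl compounds read alike.

Open, from the compounds shown here alone, is whether this saturated carbon accepts more than phenyl, for instance a longer chain or an amine in place of the same hydrogen. Also open, going by these compounds, is whether a carboxylic acid or a fluorine on the added phenyl ring would keep the number within the scatter of compound 3 or move it beyond.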